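The source may report more compounds than this note shows. Statements on the series, on what has been measured and on what is new or still open speak of the compounds shown alone.

In an ADME assay (liver) for metabolic stability, with Liver microsome (Homo sapiens) as the target, read by LC-MS, using microsomes, tested at 1 uM (on this read-out higher numbers stand for a longer-lived compound and lower numbers for a shorter-lived compound), compound 1 `C/C(=N/c1ccnc2cc(Cl)ccc12)NCCCCN1CCCCC1` gives > 1 h, which is a limit of the assay and not a number. For the measured compounds named here, compound 2 `CC(C)/C(=N/c1ccnc2cc(Cl)ccc12)NCCCCN1CCCCC1`, with isopropyl in place of methyl on a carbon with a double bond to nitrogen, gives 0.483 h, the only true number so far. That swap is an at least 2.0-fold lower number from compound 1 to compound 2 (0.31 log units; beyond the scatter). Compound 3 `CCN(CC)CCN/C(=N\c1ccnc2cc(Cl)ccc12)C(C)C` keeps the isopropyl and differs elsewhere: diethylamino in place of 2-(piperidin-1-yl)ethyl on a saturated chain carbon, two bonds along the chain from an amine nitrogen. In words, this is diethylamino in place of 2-(piperidin-1-yl)ethyl on a saturated chain carbon, two bonds along the chain from an amine nitrogen. Going by the values given here, the one measured step lies at a different place, so it shows only that a single change can move this assay beyond the scatter, and it gives no direction for this one. The estimated step is a 1.1-fold higher number from compound 2 to compound 3 (0.06 log units; within the scatter), with none expected beyond the scatter. For compound 3 the expected half-life is 0.55 h, within an estimated range of 0.25 h to 1 h.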

Compound 3, half-life: > 1 h
Compound 3: only a limit was reported; the forecaster's own chance of this, stated with the estimate: 15%; at least 1.8-fold (0.25 log units) between middle value and limit.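

The earlier pair showed a change only at the carbon with a double bond to nitrogen, whereas this swap at the far end of the side chain, with the isopropyl kept, gives an at least 2.0-fold higher number from compound 2 to compound 3 (0.31 log units; beyond the scatter) in this assay. Compound 3 gives > 1 h, which is a limit of the assay and not a number. The step therefore marks only the smallest gap the data allow, and the true size stays hidden: the limit of > 1 h in this assay, at which 2 of the 3 values shown sit.

This one swap removes the six-membered ring and also takes the group from 8 heavy atoms to 5, and the compounds shown do not separate those two differences. Going by these compounds, how a morpholine ring at this place, or a longer chain ending in diethylamino, would read remains open.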